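The source may report more compounds than this note shows. Statements on the series, on what has been measured and on what is new or still open speak of the compounds shown alone.

Measured compounds in a functional assay on the whole organism (strain Wistar) for inhibition, with Rattus norvegicus as the target, read by paw edema, with stated times of 60 min and 1 h, at a dose of 100 mg/kg by the oral route; on this read-out higher numbers stand for more inhibition at the one dose given (going by the name of the read-out) and lower numbers for less inhibition:
compound 1 `COc1cc2c(cc1OC)C(CC(=O)O)CC2` gives 18.8%
compound 2 `COc1cc2c(cc1OC)C(CC(=O)NC(C)C)CC2` gives 31.3%

Within the data shown here, compound 2 stands highest of the two numbers in this assay; its nearest neighbour is compound 1, and the single measured step runs a number 12.5 percentage points higher from compound 1 to compound 2 (beyond the scatter), a change of isopropylamino in place of hydroxy on a carbonyl carbon. Compound 3 `CCCCNC(=O)CC1CCc2cc(OC)c(OC)cc21` has not been measured in this assay. Its difference from compound 2 is butyl in place of isopropyl on an amide-type nitrogen. Among the measured compounds shown here, no measured step shows how a change on the amide-type nitrogen itself plays out in this assay: the only step known concerns the carbonyl carbon, not the group carried by the nitrogen, so it does not bear directly on this change. With nothing to point either way, the expected step for compound 3 is a number 0.3 percentage points lower from compound 2 to compound 3 (within the scatter), that is, no change beyond the scatter. Compound 3 is therefore estimated at 31%, within a range of 15% to 47%.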

Compound 3, a percentage reported as inhibition, in the whole organism at one dose (the size of the read-out at that dose, not a potency): 31.3%
Compound 3: middle estimate off by 0.3 percentage points, on the low side; low and high end bracket the measured number.
By their numbers in this assay, from the lowest: compound 1; then compounds 2 and 3 (each within the scatter of the next).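

In this assay, the first reading on the amide-type nitrogen itself shows that butyl can stand in place of isopropyl with no change at the digits printed from compound 2 to compound 3 (within the scatter), so among these two groups the choice leaves the read-out unmoved. Butylamino in place of hydroxy on the carbonyl carbon gives a number 12.5 percentage points higher from compound 1 to compound 3 (beyond the scatter), which shows that the rise seen with isopropylamino also appears with a second amide and is not confined to that one group. Nothing available here explains why the two groups read alike. The compounds shown leave open whether a longer chain such as octyl, a benzyl group or a chain ending in an amine on that nitrogen would shift the inhibition of paw edema. They also leave open what a second alkyl group on the same nitrogen would do.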